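Replacing the thiophene ketone with a pyrrole ketone

The source may hold more compounds than are shown below. What is called first, only, known or untested is meant among the compounds shown, and "the series" means these compounds.

Compound 3 `COc1ccc(-c2cc3ccccc3nc2/C=C/C(=O)c2cccs2)cc1` carries the lowest number of the three measured in a functional assay on MCF7 cells (Homo sapiens) for antiproliferative activity, read by XTT assay, with a stated time of 72 h; a higher number here means a weaker inhibitor, a lower number a stronger inhibitor: compound 3 gives 1030 nM, whereas compound 1 `COc1ccc(C(=O)/C=C/c2nc3ccccc3cc2-c2ccc(OC)cc2)cc1` gives 7380 nM and compound 2 `COc1ccc(-c2cc3ccccc3nc2/C=C/C(=O)c2ccc(OC)c(OC)c2)cc1` gives 6030 nM. Both measured steps that reach compound 3 change the group on the carbonyl carbon: a 7.2-fold lower number from compound 1 to compound 3 (0.86 log units; beyond the scatter) and a 5.9-fold lower number from compound 2 to compound 3 (0.77 log units; beyond the scatter), while a 1.2-fold lower number from compound 1 to compound 2 (0.09 log units; within the scatter) is a change elsewhere. Compound 4 `COc1ccc(-c2cc3ccccc3nc2/C=C/C(=O)c2ccc[nH]2)cc1` differs from compound 3 only at that same carbonyl carbon: 1H-pyrrol-2-yl in place of thiophen-2-yl on a carbonyl carbon. Among the measured compounds shown here, no measured step swaps one five-membered ring for another at this position; the two steps onto compound 3 only show that the group on the carbonyl carbon can move this assay modestly. For the measured compounds named here, with no direct precedent, the step from compound 3 to compound 4 is expected to be small, a 1.5-fold higher number from compound 3 to compound 4 (0.16 log units; within the scatter), with a slight lean toward a higher number. Compound 4 is therefore estimated at 1500 nM in this assay, within a range of 500 nM to 4500 nM.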

Compound 4, half-maximal inhibitory concentration: > 10000 nM
Compound 4: only a limit was reported; the forecaster's own chance of this, stated with the estimate: 3%; middle value at least 6.6-fold (0.82 log units) from the limit.
By their numbers in this assay, from the lowest: compound 3; then compounds 2 and 1 (each within the scatter of the next). At a limit, above all of these: compound 4.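

Compound 4 is reported only as a limit, so every step onto it gives a floor, not a size: the limit of > 10000 nM in this assay, at which 1 of the 4 values shown sits.

Even as a floor, the exchange in this assay between two five-membered aromatic rings, each with 1 hetero atom, is not neutral on this carbonyl carbon: an at least 9.7-fold higher number from compound 3 to compound 4 (0.98 log units; beyond the scatter). The low number of compound 3 therefore does not extend to every five-membered ring here, while an at least 1.6-fold higher number from compound 2 to compound 4 (0.21 log units; that floor lies within the scatter) and an at least 1.3-fold higher number from compound 1 to compound 4 (0.13 log units; that floor lies within the scatter) are floors that leave the order of compound 4 against the two aryl ketones unresolved.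

The compounds shown do not separate the effect of the ring nitrogen from that of its hydrogen. From the compounds shown here alone, a 1-methylpyrrol-2-yl or furan-2-yl group on the same carbonyl carbon would bear on that question, and how far compound 4 lies past its limit remains open.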